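From a 2-fluorobenzyl to a 4-bromobenzyl group

The compounds below may be only part of what the source reports. "The series", "measured", "known", "first", "only" and "open" are said of these compounds alone.

- compound 1 `CC(C)(C)c1cc(CCC(=O)NC2CCN(Cc3ccccc3)CC2)cc(C(C)(C)C)c1O` gives 80300 nM
- compound 2 `CC(C)(C)c1cc(/C=C/C(=O)NCC2CCN(Cc3ccccc3)CC2)cc(C(C)(C)C)c1O` gives 75600 nM
- compound 3 `CC(C)(C)c1cc(/C=C/C(=O)NCCC2CCN(Cc3ccccc3F)CC2)cc(C(C)(C)C)c1O` gives 55900 nM

All three values come from a functional assay, read by spectrophotometry, with a stated time of 30 min (on this read-out lower numbers stand for stronger inhibition and higher numbers for weaker inhibition), and lie within the usual scatter of one another. Compound 3 (55900 nM) stands within the scatter of compound 1 and of compound 2, so the numbers do not separate the three.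

Compound 4 `CC(C)(C)c1cc(/C=C/C(=O)NCCC2CCN(Cc3ccc(Br)cc3)CC2)cc(C(C)(C)C)c1O` has not yet been measured. It keeps the structure of compound 3 except for one change, 4-bromophenyl in place of 2-fluorophenyl on a saturated chain carbon bound to an amine nitrogen in a ring (on a saturated chain carbon bound to an amine nitrogen in a ring). Cut one bond further out, the same change reads 2-fluorobenzyl to 4-bromobenzyl.

Among the compounds with values here, no two measured compounds differ in only one place, so the data give no direct measure of such a change. The expectation rests on compound 3 (55900 nM) and its closeness to compound 2 (75600 nM) despite their differences in structure. No step beyond the scatter is expected in this assay and no direction is favoured, the estimated step being a 1.2-fold lower number from compound 3 to compound 4 (0.09 log units; within the scatter) and no more. The estimate for compound 4 is 45000 nM (expected range 15000 nM to 100000 nM).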

Compound 4, half-maximal inhibitory concentration: 85600 nM
Beside the measured number, compound 4's estimate is 1.9-fold (0.28 log units) below it; low and high end bracket the measured number.
By their numbers in this assay, from the lowest: compounds 3, 2, 1 and 4 (each within the scatter of the next).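

In this assay, within the data shown here, putting 4-bromophenyl in place of 2-fluorophenyl on a saturated chain carbon bound to an amine nitrogen in a ring gives a 1.5-fold higher number from compound 3 to compound 4 (0.19 log units; within the scatter), and this pair is the first in the set to differ in only one place. Among these compounds, the earlier compounds could show only that numbers lay close together across several structural differences, whereas this step isolates one position and shows that this exchange, with the heavy-atom count unchanged, does not move the result beyond the scatter. Nothing available here gives a reason for the size of the step.

The change replaces the halogen and alters its place on the ring in a single move, so this pair cannot show whether either alteration alone would matter, or whether two opposing contributions are hidden within the small step; 4-fluorophenyl and 2-bromophenyl would separate them. On these data alone, it also remains open whether this position can respond at all in this assay, since all the groups here are halogen-bearing or plain aromatic rings, and a nitrile, a carboxylic acid or an amine on that ring would test a different kind of substituent.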